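Phenyl removal on the aminobenzamide of compound 2

This account rests on a few compounds, and the source may have more. Where it says the series, first, only, none or still open, it means among the compounds named here.

Three compounds built on one shared core differ only in the length of the chain joining their two amide groups. Compound 1 `CCOc1cc(NC(=O)CCCCCC(=O)Nc2cc(-c3ccccc3)ccc2N)cc2c1OCC([N+](=O)[O-])=C2` gives 28% in an assay on isolated protein for inhibition of protein deacetylase HDAC6 (Homo sapiens), read by fluorescence, with stated times of 10 min and 30 min, tested at 10 uM (on this read-out lower numbers stand for less inhibition and higher numbers for more inhibition at the one concentration tested (going by the name of the read-out)), compound 3 `CCOc1cc(NC(=O)CCCCCCC(=O)Nc2cc(-c3ccccc3)ccc2N)cc2c1OCC([N+](=O)[O-])=C2` gives 29%, and compound 2 `CCOc1cc(NC(=O)CCCCC(=O)Nc2cc(-c3ccccc3)ccc2N)cc2c1OCC([N+](=O)[O-])=C2` gives 25%. Compound 2 thus sits at the low end of the three, yet its gaps to compound 1 and to compound 3 both fall within the usual scatter, so these data do not separate the three. Compound 4 `CCOc1cc(NC(=O)CCCCC(=O)Nc2ccccc2N)cc2c1OCC([N+](=O)[O-])=C2` has not been measured. It differs from compound 2 in one place: hydrogen in place of phenyl on an aromatic carbon. For the measured compounds named here, no pair of measured compounds shares this change, so nothing measured tells how large a step it brings. A modest decrease is nonetheless expected, with the step from compound 2 to compound 4 estimated at a number 8 percentage points lower from compound 2 to compound 4 (within the scatter). Compound 4 is expected to give 17% in this assay, within a range from 5% to 30%.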

Compound 4, a percentage reported as inhibition, at one concentration (the size of the read-out at that concentration, not a potency): 68%
Estimate against measurement, compound 4: 51 percentage points below, and the stated range ends below it.
By their numbers in this assay, from the lowest: compounds 2, 1 and 3 (each within the scatter of the next); then compound 4.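

Replacing phenyl with hydrogen on the aromatic carbon para to an amino group brings a number 43 percentage points higher from compound 2 to compound 4 (beyond the scatter) in this assay and so opens a gap that the three chain lengths did not produce. This position therefore matters far more for the read-out than anything varied among compounds 1, 2 and 3, whose values could not be separated, and the phenyl is not needed for inhibition at the one concentration tested. No measurement at hand bears on why the change has this effect.

What a methyl group, a fluorine atom or a methoxy group on this carbon would bring remains open, so the compounds shown do not place the step between its two ends. Also open, on these data alone, is whether the chains of compound 1 and compound 3 would give a similar reading with hydrogen at this place.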